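The source may report more compounds than this note shows. Statements on the series, on what has been measured and on what is new or still open speak of the compounds shown alone.

Working notes on the series. The shared core is that of compound 1 `CC(C)(C)c1ccc(NC(=O)c2ccc(-c3ncccc3C#N)cc2)cc1`, which in a functional assay for antagonist activity at transient receptor potential cation channel subfamily V member 1 (Rattus norvegicus) (on this read-out higher numbers stand for weaker inhibition and lower numbers for stronger inhibition), gives 13 nM. Compound 2 `CC(C)(C)c1ccc(NC(=O)c2ccc(-c3ncccc3C(=N)N)cc2)cc1` sits at the limit of > 4000 nM in this assay, at which 1 of the 2 values shown sits, in this assay. The reading for compound 2 of > 4000 nM is a limit of the assay, not a number. Within the data shown here, the single measured step, an at least 300-fold higher number from compound 1 to compound 2 (2.48 log units; beyond the scatter), is accordingly known only as a bound; it is large. Compound 3 `CN(C)Cc1cccnc1-c1ccc(C(=O)Nc2ccc(C(C)(C)C)cc2)cc1` differs from compound 2 by a group of 4 heavy atoms (3 carbon, 1 nitrogen; no ring) in place of a group of 3 heavy atoms (1 carbon, 2 nitrogen; no ring), on an aromatic carbon. Among the measured compounds shown here, only the step from compound 1 to compound 2 bears on this change, and it carries no information on the (dimethylamino)methyl group itself, so the size of the coming step is uncertain in both directions. The step expected in this assay is an at least 2.6-fold lower number from compound 2 to compound 3 (0.42 log units; beyond the scatter). Compound 3 is estimated at 1500 nM, in the range 200 nM to 8000 nM, with a real chance that this assay again returns only a limit.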

Compound 3, half-maximal inhibitory concentration: 234 nM
Compound 3: the middle estimate sits 6.4-fold (0.81 log units) above what was measured; low and high end bracket the measured number.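

The position accepts more than one replacement of cyano: in this assay (dimethylamino)methyl gives a measured number, so the collapse seen with compound 2 does not extend to every group placed here. Even so, the change carries a large cost, an 18-fold higher number from compound 1 to compound 3 (1.26 log units; beyond the scatter), and cyano remains the best of the three groups shown. The step of an at least 17-fold lower number from compound 2 to compound 3 (1.23 log units; beyond the scatter) is only a bound, since the reading for compound 2 is a limit of the assay and not a number: the limit of > 4000 nM in this assay, at which 1 of the 3 values shown sits.

Going by these compounds, whether the result depends on the two methyl groups on the nitrogen or on the methylene spacer stays open, and aminomethyl or a longer chain such as 2-(dimethylamino)ethyl would test this. On these data alone, how a carboxylic acid, a primary amide or a halogen would fare at this position also remains unknown.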